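A Single Weak Value and One Change on the Chain

The compounds below may be only part of what the source reports. "The series", "measured", "known", "first", "only" and "open" are said of these compounds alone.

The study records cytotoxicity in a functional assay on A549 cells (Homo sapiens) for cytotoxicity, read by MTT assay, with a stated time of 72 h; a higher number here means a weaker inhibitor, a lower number a stronger inhibitor. Compound 1 `COc1cc2ncnc(Nc3ccc(F)c(Cl)c3)c2cc1NC(=O)/C=C/c1ccc(F)cc1Cl` gave no number there and was recorded as "not active" (no number reported). Going by the values given here, compound 2 `O=C(/C=C/c1cc(Br)c(O)c(Br)c1)Nc1cc2c(Nc3ccc(F)c(Cl)c3)ncnc2cc1O[C@H]1CCOC1` is the only compound with a figure: in this assay compound 2 gives 28800 nM, so compound 2 stands alone on the numbers and there is no second measured value to set it against. Compound 3 `O=C(/C=C/c1ccc(Br)cc1)Nc1cc2c(Nc3ccc(F)c(Cl)c3)ncnc2cc1O[C@H]1CCOC1` has not yet been measured. It differs from compound 2 in one place: 4-bromophenyl in place of 3,5-dibromo-4-hydroxyphenyl on a double-bonded chain carbon bound to a double-bonded chain carbon. Among the compounds with values here, no step between measured compounds is available to show how large a change of this kind tends to be here, and the only known value, that of compound 2 at 28800 nM, already sits far toward the weak end. Compound 3 is therefore expected to land in the same region, with any step from compound 2 to compound 3 estimated at a 1.4-fold higher number from compound 2 to compound 3 (0.14 log units; within the scatter), most likely no larger than the scatter and, if anything, toward weaker. Compound 3 is estimated at 40000 nM in this assay, within a range of 10000 nM to 150000 nM.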

Compound 3, half-maximal inhibitory concentration: 35300 nM
Compound 3: the middle estimate sits 1.1-fold (0.05 log units) above what was measured; low and high end bracket the measured number.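

Going by these compounds alone, the first comparison at this position comes from the pair compound 2 and compound 3: in this assay the change reads as a 1.2-fold higher number from compound 2 to compound 3 (0.09 log units; within the scatter) and so does not separate the two compounds. On a double-bonded chain carbon bound to a double-bonded chain carbon, then, 4-bromophenyl and 3,5-dibromo-4-hydroxyphenyl cannot be told apart in this read-out, even though the group that leaves has 1 hydrogen-bond donor and 1 hydrogen-bond acceptor and the group that enters has neither. Nothing measured here accounts for this result, and the pair alone gives no reason for it.

The hydroxyl group and the bromine atoms differ together in this single pair, so what each would do alone remains unresolved, and one pair cannot show whether this position is insensitive to change in general. Also open, going by these compounds, is whether an amine or a carboxylic acid on the phenyl ring, or a longer chain carrying that ring, would give a step beyond the scatter in this assay at all.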